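Adding phenyl to the amide-type nitrogen of compound 3

This account rests on a few compounds, and the source may have more. Where it says the series, first, only, none or still open, it means among the compounds named here.

Measured in a functional assay on MCF7 cells (Homo sapiens) for antiproliferative activity, read by MTT assay, with a stated time of 72 h (on this read-out lower numbers stand for stronger inhibition and higher numbers for weaker inhibition), are these compounds:
compound 1 `O=C1COc2ccc(-c3cccc(NS(=O)(=O)c4ccc(F)cc4)c3)cc2N1` gives 18300 nM
compound 2 `COc1ccc(N2C(=O)COc3ccc(-c4ccc(O)cc4)cc32)cc1` gives 17300 nM
compound 3 `COc1ncc(-c2ccc3c(c2)NC(=O)CO3)cc1NS(=O)(=O)c1ccc(F)cc1` gives 32300 nM

Compound 3 at 32300 nM lies within the scatter of both compound 1 and compound 2, so the three do not separate. Compound 4 `COc1ncc(-c2ccc3c(c2)N(c2ccccc2)C(=O)CO3)cc1NS(=O)(=O)c1ccc(F)cc1` follows from compound 3 by phenyl in place of hydrogen on an amide-type nitrogen in a ring and so carries phenyl in place of hydrogen on an amide-type nitrogen in a ring. Among the measured compounds shown here, no measured pair shows this change. Compound 2 also bears an aromatic ring on such a nitrogen, yet at 17300 nM it stays within the scatter of compound 3, so the guidance is weak. A lower number beyond the scatter is nevertheless expected, with the estimate being a 5.4-fold lower number from compound 3 to compound 4 (0.73 log units; beyond the scatter) in this assay on this slight evidence. For compound 4 the estimated value is 6000 nM with an expected range of 600 nM to 30000 nM.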

Compound 4, half-maximal inhibitory concentration: 8870 nM
Estimate against measurement, compound 4: 1.5-fold (0.17 log units) below; the measured number falls inside the stated range.
By their numbers in this assay, from the lowest: compounds 4, 2, 1 and 3 (each within the scatter of the next, the first and the last beyond it).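

In this assay, phenyl in place of the amide hydrogen gives a 3.6-fold lower number from compound 3 to compound 4 (0.56 log units; beyond the scatter) and thus provides the first step among these compounds, showing that this nitrogen is a place where the change moves the number beyond the scatter. The lower number also shows that a phenyl ring is accepted on this nitrogen in this series. Nothing given here accounts for the step. As far as these compounds go, whether a methyl group, a benzyl group or a pyridyl ring on this nitrogen would give a step of like size stays open. So does whether phenyl would act the same way on compound 1.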